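The compounds below may be only part of what the source reports. "The series", "measured", "known", "first", "only" and "open" are said of these compounds alone.

Within the data shown here, compound 2 `CC[C@H](C)[C@H](N)CN(C(=O)[C@@H]1C[C@H]1c1cccc(OC)c1)c1ccc(-c2ccccc2)cc1` gives 3000 nM in a functional assay for agonist activity at G protein-coupled receptor 88 (Homo sapiens), read by HTRF and cAMP accumulation (a lower number here means that less compound is needed, a higher number that more compound is needed for the effect), the higher of the two numbers known so far. Compound 1 `N[C@H](CN(C(=O)[C@@H]1C[C@H]1c1ccccc1)c1ccc(-c2ccccc2)cc1)C1CCCCC1` gives 0.66 nM in this assay; it differs from compound 2 in more than one place, so the gap between the two cannot be laid on any single change. Compound 3 `CC[C@H](C)[C@H](N)CN(C(=O)[C@@H]1C[C@H]1c1cccs1)c1ccc(-c2ccccc2)cc1` differs from compound 2 by thiophen-2-yl in place of 3-methoxyphenyl on a saturated ring carbon. Among the measured compounds shown here, no measured pair shows this change, so the step of a 3.0-fold lower number from compound 2 to compound 3 (0.48 log units; beyond the scatter) is an expectation only, set at a modest gain that may still sit within the scatter. For compound 3 the expected value in this assay is 1000 nM, within 100 nM to 10000 nM.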

Compound 3, half-maximal effective concentration: 360 nM
For compound 3 the middle estimate is 2.8-fold (0.44 log units) above the measured one; measured number inside the range.
By their numbers in this assay, from the lowest: compound 1; then compound 3; then compound 2.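

In this assay, the saturated ring carbon of the three-membered ring responds to a single change: thiophen-2-yl in place of 3-methoxyphenyl gives an 8.3-fold lower number from compound 2 to compound 3 (0.92 log units; beyond the scatter). Among these compounds, this is the first step that can be laid on one change, and it shows that the 3-methoxyphenyl group is not required for the effect at this position. No measurement at hand accounts for the step. Still open, as far as these compounds go, is whether the step belongs to the thiophen-2-yl ring itself or to the loss of the methoxy group; thiophen-3-yl or a pyridine ring on this carbon would bear on that.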